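From a propyl amide to a benzamide on the shared core

A few compounds are considered here, and "the series" means these few. Any claim that something is new, unique, unknown or untested is made for them only; others in the source may bear on it.

Measured compounds:
compound 1 `COc1cc(/C=C/C(=O)c2cccc(NC(=O)c3ccc(Cl)c(Cl)c3)c2)ccc1O`: 45%
compound 2 `CCCC(=O)Nc1cccc(C(=O)/C=C/c2ccc(O)c(OC)c2)c1`: 87%

In a functional assay on HUVEC cells (Homo sapiens) for inhibition, tested at 10 ug/mL (on this read-out lower numbers stand for a weaker effect and higher numbers for a stronger effect at the one concentration tested), compound 2 gives 87%, the higher of the two numbers, while compound 1 gives 45%. Compound 3 `COc1cc(/C=C/C(=O)c2cccc(NC(=O)c3ccccc3)c2)ccc1O` carries the change (phenyl in place of propyl on a carbonyl carbon). Going by the values given here, the only step that bears on it is a number 42 percentage points higher from compound 1 to compound 2 (beyond the scatter), where an aromatic ring left and a short chain entered. Compound 3 reverses part of that, putting an aromatic ring back without chlorines, so a moderate drop is expected: a number 25 percentage points lower from compound 2 to compound 3 (beyond the scatter). Compound 3 is therefore estimated at 62%, within a range from 40% to 82%.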

Compound 3, a percentage reported as inhibition, at one concentration (the size of the read-out at that concentration, not a potency): 69%
The estimate for compound 3 lay 7 percentage points below the measured number; the measured number falls inside the stated range.
By their numbers in this assay, from the lowest: compound 1; then compound 3; then compound 2.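

In this assay, phenyl in place of propyl on this carbonyl carbon gives a number 18 percentage points lower from compound 2 to compound 3 (beyond the scatter) and shows that a plain aromatic ring already accounts for part of the loss seen with compound 1. Phenyl in place of 3,4-dichlorophenyl gives a number 24 percentage points higher from compound 1 to compound 3 (beyond the scatter) and shows that the two chlorines account for a further part. Among these three compounds, the short propyl chain therefore stands highest, the plain ring in the middle and the dichlorinated ring lowest.

As far as these compounds go, whether a longer chain, such as hexyl, or a chain ending in an amine would match compound 2 stays open. No measurement shown explains either step.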